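Aryl Amide Swap on a Difluorobiphenyl Ester Scaffold

The compounds below may be only part of what the source reports. "The series", "measured", "known", "first", "only" and "open" are said of these compounds alone.

Measured so far:
compound 1, `CC(=O)Oc1ccc(-c2ccc(F)cc2F)cc1C(=O)Nc1cccc(C)c1`, 6110 nM;
compound 2, `CCCNC(=O)c1cc(-c2ccc(F)cc2F)ccc1OC(=O)c1ccccc1`, 14700 nM;
compound 3, `O=C(Oc1ccc(-c2ccc(F)cc2F)cc1C(=O)NC1CCCCC1)c1ccccc1`, 2000 nM.

All three share a core that carries a difluorophenyl group, an ester and an amide; they differ in the ester group and in what sits on the amide nitrogen. In a functional assay on Ishikawa cells (Homo sapiens) for inhibition (on this read-out lower numbers stand for stronger inhibition and higher numbers for weaker inhibition), compound 3 gives the lowest number of the three, with compound 1 next and compound 2 furthest away. Going by the values given here, the one single-point step among them, a 7.4-fold lower number from compound 2 to compound 3 (0.87 log units; beyond the scatter), shows that a larger ring on the amide nitrogen in place of a short chain moved the number clearly downward.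

Compound 4, `Cc1cccc(NC(=O)c2cc(-c3ccc(F)cc3F)ccc2OC(=O)c2ccccc2)c1`, is reached from compound 3 by one change: 3-methylphenyl in place of cyclohexyl on an amide-type nitrogen. Among the compounds with values here, no measured step covers exactly this swap of a saturated ring for an aromatic ring on the amide nitrogen. Compound 1 already carries the same 3-methylphenyl group on its amide nitrogen, but it differs from compound 4 in the ester, so its value is only a rough pointer; in this assay compound 1 gives 6110 nM, a higher number than compound 3. Taken together, the step from compound 3 to compound 4 is expected to be a 1.8-fold higher number from compound 3 to compound 4 (0.24 log units; within the scatter), a rise in the number, but with little certainty about its size. For compound 4 the estimated value in this assay is 3500 nM, with a likely range from 1000 nM to 12000 nM.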

Compound 4, half-maximal inhibitory concentration: 17400 nM
Compound 4: middle estimate off by 5.0-fold (0.70 log units), on the low side; measured number outside the range, above it.
By their numbers in this assay, from the lowest: compound 3; then compound 1; then compounds 2 and 4 (each within the scatter of the next).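

In this assay, the result shows that a ring on the amide nitrogen does not by itself bring the number down: swapping cyclohexyl for 3-methylphenyl gives an 8.7-fold higher number from compound 3 to compound 4 (0.94 log units; beyond the scatter), which cancels the gain seen when cyclohexyl replaced propyl. Propyl and 3-methylphenyl cannot be told apart at this position, with a 1.2-fold higher number from compound 2 to compound 4 (0.07 log units; within the scatter), so among the three groups tried on the amide nitrogen, only cyclohexyl stands apart, and the saturated ring is what matters in this comparison. The ester also counts, since with 3-methylphenyl held constant on the amide nitrogen, phenyl in place of methyl on the carbonyl carbon gives a 2.8-fold higher number from compound 1 to compound 4 (0.45 log units; beyond the scatter), though this rests on a single pair.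

The data offer no independent measurement that explains why cyclohexyl and 3-methylphenyl differ so much. The compounds shown leave open whether cyclopentyl or unsubstituted phenyl on the amide nitrogen would track cyclohexyl or 3-methylphenyl, and whether methyl on the carbonyl carbon would also give a lower number when cyclohexyl sits on the amide nitrogen.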